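The source may hold more compounds than are shown below. What is called first, only, known or untested is meant among the compounds shown, and "the series" means these compounds.

In a functional assay on MCF7 cells (Homo sapiens) for antiproliferative activity, read by CCK-8 assay, with a stated time of 72 h (a lower number here means a stronger inhibitor, a higher number a weaker inhibitor), the measured compounds stand as follows:
compound 1 `Cc1cc(Nc2cc(N3CCN(C)CC3)nc(Nc3ccc([N+](=O)[O-])cc3)n2)n[nH]1` gives 424 nM
compound 2 `COc1cccc(Nc2nc(Nc3cc(C)[nH]n3)cc(N3CCN(C)CC3)n2)c1` gives 933 nM

Of these two numbers, the higher belongs to compound 2 at 933 nM, which makes it the weaker inhibitor of the pair. Compound 3 `Cc1cc(Nc2cc(N3CCN(C)CC3)nc(Nc3cccc(Cl)c3)n2)n[nH]1` differs from compound 2 in one place, with chloro in place of methoxy on an aromatic carbon, meta to a large group: chloro in place of methoxy on an aromatic carbon. Going by the values given here, only one measured step bears on this change, a 2.2-fold higher number from compound 1 to compound 2 (0.34 log units; beyond the scatter), in which 3-methoxyphenyl stands in place of 4-nitrophenyl on a nitrogen on an aromatic ring. Among the compounds with values here, that step is modest, though it concerns a different pair of groups, and no measured compound carries chloro. The data therefore give only weak guidance on direction. In this assay a small move toward a lower number is expected, most likely staying within the scatter and smaller than the step seen from the nitro compound. The expected change is a 1.3-fold lower number from compound 2 to compound 3 (0.11 log units; within the scatter). For compound 3 the estimate is 720 nM, with an expected range of 330 nM to 1600 nM.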

Compound 3, half-maximal inhibitory concentration: 436 nM
Compound 3: middle estimate off by 1.7-fold (0.22 log units), on the high side, within the range that was stated.
By their numbers in this assay, from the lowest: compounds 1 and 3 (each within the scatter of the next); then compound 2.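

In this assay, a change at this aromatic carbon, meta to a large group, can now be read on its own: with the rest of the molecule unchanged, chloro in place of methoxy gives a 2.1-fold lower number from compound 2 to compound 3 (0.33 log units; beyond the scatter), a modest step beyond the scatter. The earlier step between compound 1 and compound 2 changed both the group and its place on the phenyl ring, whereas a 1.0-fold higher number from compound 1 to compound 3 (0.01 log units; within the scatter) shows that 3-chlorophenyl and 4-nitrophenyl cannot be told apart here, which leaves compound 2, with its 3-methoxyphenyl, as the one with the higher number among these three. The available data offer no explanation for the difference between methoxy and chloro at this position.

The compounds shown leave open how fluoro, bromo, an amine or a carboxylic acid on this same carbon would compare with chloro. They also leave open whether chloro would give a similar number if moved to another carbon of the phenyl ring, and whether the step from methoxy to chloro would hold in other cell lines.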